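Methyl in place of bromo on an indole methanol

The source may hold more compounds than are shown below. What is called first, only, known or untested is meant among the compounds shown, and "the series" means these compounds.

The measured compounds, all tested in an ADME assay on T29 cells (Homo sapiens) for cytotoxicity, read by sulforhodamine B assay, with a stated time of 3 days; on this read-out higher numbers stand for weaker inhibition and lower numbers for stronger inhibition:

Compound 1, `OCc1cn(Cc2cccc(Br)c2)c2ccccc12`. In this assay compound 1 gives only a limit, > 31600 nM.
Compound 2, `OCc1cn(Cc2ccc(Br)cc2)c2ccccc12`. In this assay compound 2 gives only a limit, > 31600 nM.
Compound 3, `Cc1cccc(Cn2cc(CO)c3ccccc32)c1`. In this assay compound 3 gives only a limit, > 31600 nM.

Compounds 1 and 2 have the same atoms joined differently; the difference between their two cores is not broken down here. From compound 1 to compound 3 the change is methyl in place of bromo on an aromatic carbon, and it gives a step that the two limits leave unreadable from compound 1 to compound 3.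

Compound 4, `Cc1ccc(Cn2cc(CO)c3ccccc32)cc1`, is not yet measured. It differs from compound 2 by methyl in place of bromo on an aromatic carbon. Among the measured compounds shown here, this is the same kind of change as the one from compound 1 to compound 3, though the place differs: there the methyl sits meta to a large group, here para to a large group.

Because (the limit of > 31600 nM in this assay, at which 3 of the 3 values shown sit), compound 4 is expected to give 40000 nM in this assay, most likely again only a limit. The expected step is a step that the limit leaves unreadable from compound 2 to compound 4, with an expected range from 20000 nM to 100000 nM.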

Compound 4, half-maximal inhibitory concentration: > 31600 nM
Compound 4: only a limit was reported (the forecaster's own chance of this, stated with the estimate: 85%); the middle value lies beyond the limit too.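

No size can be read for the change from bromo to methyl between compound 2 and compound 4, or for the same change between compound 1 and compound 3, because each value is only a limit: the limit of > 31600 nM in this assay, at which 4 of the 4 values shown sit.

The compounds shown leave open how strongly any of them acts in this assay, and so whether methyl in place of bromo changes anything there at all.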